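The source may hold more compounds than are shown below. What is called first, only, known or untested is meant among the compounds shown, and "the series" means these compounds.

Measured compounds: compound 1 `O=C(Nc1cccc(/C=C/C(=O)c2nc3ccccc3[nH]2)c1)c1ccc(Cl)cc1` gives 7440 nM; compound 2 `O=C(Nc1cccc(/C=C/C(=O)c2nc3ccccc3[nH]2)c1)c1ccc(Br)cc1` gives 7310 nM; compound 3 `O=C(/C=C/c1cccc(NS(=O)(=O)c2cccc(Cl)c2)c1)c1nc2ccccc2[nH]1` gives 2510 nM — all in a functional assay on 143B cells (Homo sapiens) for antiproliferative activity, read by MTT assay, with a stated time of 48 h; on this read-out higher numbers stand for weaker inhibition and lower numbers for stronger inhibition.

Compound 2 holds the second highest of the three numbers, with compound 1 within the scatter and compound 3 the only one set apart, the step of a 2.9-fold lower number from compound 2 to compound 3 (0.46 log units; beyond the scatter).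

Compound 4 `Cc1ccccc1S(=O)(=O)Nc1cccc(/C=C/C(=O)c2nc3ccccc3[nH]2)c1` carries the change ((2-methylphenyl)sulfonyl in place of (4-bromophenyl)carbonyl on a nitrogen on an aromatic ring).

Going by the values given here, two measured steps bear on it: a 2.9-fold lower number from compound 2 to compound 3 (0.46 log units; beyond the scatter) and a 3.0-fold lower number from compound 1 to compound 3 (0.47 log units; beyond the scatter), both the same move from a carbonyl to a sulfonyl on that nitrogen, each modest and beyond the scatter. Among the compounds with values here, compound 4 repeats that move but with (2-methylphenyl)sulfonyl rather than (3-chlorophenyl)sulfonyl, a change for which no pair exists here. A modest lowering is expected, the step of a 2.3-fold lower number from compound 2 to compound 4 (0.36 log units; beyond the scatter).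

Compound 4 is estimated at 3200 nM, range 1500 nM to 6800 nM.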

Compound 4, half-maximal inhibitory concentration: 4060 nM
Estimate against measurement, compound 4: 1.3-fold (0.10 log units) below; measured number inside the range.
By their numbers in this assay, from the lowest: compounds 3, 4, 2 and 1 (each within the scatter of the next, the first and the last beyond it).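

With (2-methylphenyl)sulfonyl on the nitrogen, the carbonyl-to-sulfonyl move no longer clears the scatter, at a 1.8-fold lower number from compound 2 to compound 4 (0.26 log units; within the scatter) and a 1.8-fold lower number from compound 1 to compound 4 (0.26 log units; within the scatter), so the separation seen with compound 3 does not carry over to this sulfonyl group. Replacing 3-chlorophenyl with 2-methylphenyl on the sulfonyl sulfur also stays within the scatter, at a 1.6-fold higher number from compound 3 to compound 4 (0.21 log units; within the scatter). No measurement here accounts for these steps.

As far as these compounds go, the aryl group changes whenever sulfonyl replaces carbonyl, so the share of the sulfonyl itself stays open. From the compounds shown here alone, the effect of an amine or a carboxylic acid on that ring also remains open.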